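Methoxy for methyl on the shared core

The source may hold more compounds than are shown below. What is called first, only, known or untested is meant among the compounds shown, and "the series" means these compounds.

Measured compounds:
Compound 1, `CCc1cccc2cc(-c3nn[nH]n3)cnc12`, gives 2.5 mg/kg in a functional assay on the whole organism (strain Sprague-Dawley) for inhibition, with Rattus norvegicus as the target; a lower number here means that less compound is needed, a higher number that more compound is needed for the effect.
Compound 2, `COc1ccc(OC)c2ncc(-c3nn[nH]n3)cc12`, gives 5 mg/kg in this assay.
Compound 3, `Cc1cccc2cc(-c3nn[nH]n3)cnc12`, gives < 25 mg/kg in this assay, which is a limit of the assay and not a number.

Compound 3 therefore stands only on a limit, and the step that the limit leaves unreadable from compound 1 to compound 3 has no readable size because the limit of < 25 mg/kg in this assay, at which 1 of the 3 values shown sits, hides it. Compound 4 is `COc1cccc2cc(-c3nn[nH]n3)cnc12`. Against compound 3 the change is methoxy in place of methyl on an aromatic carbon.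

Within the data shown here, no measured step follows methoxy in place of methyl directly. The nearest evidence is that compound 2, which carries methoxy groups on the core, gives 5 mg/kg, while compound 1 with an ethyl group gives 2.5 mg/kg; these two values lie within the scatter of each other, so neither substituent pattern separates from the other. Both numbers sit well inside the limit reported for compound 3.

On that basis compound 4 is expected to give a readable number near 5 mg/kg in this assay, estimated to fall between 1.5 mg/kg and 15 mg/kg. The estimated step that the limit leaves unreadable from compound 3 to compound 4 cannot be set against a measured size, since compound 3 offers only a limit; it is expected to carry compound 4 into the range where compound 1 and compound 2 sit.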

Compound 4, minimum effective dose: 2.5 mg/kg
Beside the measured number, compound 4's estimate is 2.0-fold (0.30 log units) above it, within the range that was stated.
By their numbers in this assay, from the lowest: compounds 1, 4 and 2 (each within the scatter of the next).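

Methoxy on this aromatic carbon, ortho to a fused ring, gives compound 4 a readable number in this assay, so this place accepts an oxygen-linked group as well as the ethyl of compound 1, with no change at the digits printed from compound 1 to compound 4 (within the scatter). The further hydrogen in place of methoxy elsewhere on the core does not separate the compounds either, with a 2.0-fold lower number from compound 2 to compound 4 (0.30 log units; within the scatter), so compounds 1, 2 and 4 form one group within the scatter and no order can be drawn among them. Compound 3 stands only on a limit, which is not a number, and the steps to and from it cannot be read because of that limit: the limit of < 25 mg/kg in this assay, at which 1 of the 4 values shown sits.

From the compounds shown here alone, what methyl itself contributes at this place therefore stays open, and the comparison of methyl with methoxy or ethyl has no size yet. Also open, going by these compounds, is whether the readable range holds for other groups on this aromatic carbon, such as a longer chain like propyl, an amine or a carboxylic acid, or for plain hydrogen there.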